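Indole thioacetamides: cytotoxicity limits across a benzyl swap

This account rests on a few compounds, and the source may have more. Where it says the series, first, only, none or still open, it means among the compounds named here.

Measured so far:
compound 1 `COc1ccccc1CNC(=O)CSc1c[nH]c2ccc(Br)cc12` — > 100000 nM
compound 2 `O=C(CSc1c[nH]c2c(Br)cccc12)NCc1ccc(Cl)c(Cl)c1` — > 100000 nM
compound 3 `O=C(CSc1c[nH]c2ccc(Br)cc12)NCc1ccc(Cl)c(Cl)c1` — > 100000 nM

All three values above are limits of an ADME assay on HEK-293T cells (Homo sapiens) for cytotoxicity, read by CCK-8 assay, with a stated time of 24 h (on this read-out higher numbers stand for lower toxicity in this test and lower numbers for higher toxicity in this test), rather than numbers. For compound 1 the value > 100000 nM is a limit. For compound 2 the value > 100000 nM is likewise a limit. For compound 3 the value > 100000 nM is a limit as well.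

Compound 3 and compound 1 differ by 2-methoxyphenyl in place of 3,4-dichlorophenyl on a saturated chain carbon bound to an amide-type nitrogen. The step that the two limits leave unreadable from compound 3 to compound 1 cannot be sized because the limit of > 100000 nM in this assay, at which 3 of the 3 values shown sit, holds both ends. Compound 2 and compound 3 share the same atoms joined differently; the difference between the two cores is not broken down here.

Compound 4 `COc1ccccc1CNC(=O)CSc1c[nH]c2c(Br)cccc12` is still to be measured in this assay. It differs from compound 2 by 2-methoxyphenyl in place of 3,4-dichlorophenyl on a saturated chain carbon bound to an amide-type nitrogen, the same kind of change as from compound 3 to compound 1, at the same place. The step is expected at a step that the limit leaves unreadable from compound 2 to compound 4, resting on (the limit of > 100000 nM in this assay, at which 3 of the 3 values shown sit). Compound 4 is accordingly expected at 150000 nM, most likely again as a limit, with a range from 80000 nM to 500000 nM.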

Compound 4, half-maximal cytotoxic concentration: 72400 nM
The estimate for compound 4 lay 2.1-fold (0.32 log units) above the measured number; measured number below the stated range.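

In this assay, 2-methoxyphenyl in place of 3,4-dichlorophenyl on the core of compound 2 gives an at least 1.3-fold lower number from compound 2 to compound 4 (0.14 log units; that floor lies within the scatter); this is only a floor on the step, and that floor alone does not establish a real drop. The same change on the core of compound 3 cannot be sized, because both ends of that step are limits: the limit of > 100000 nM in this assay, at which 3 of the 4 values shown sit.
Whether the change carries from one core to the other is neither shown nor excluded, as only one of the two steps has even a floor and the two cannot be compared.

The compounds shown leave open how this assay responds to other groups on a saturated chain carbon bound to an amide-type nitrogen, such as an amine or a carboxylic acid in place of the 2-methoxyphenyl. They also leave open whether any such group on the core of compound 3 would give a number rather than a limit, which a readable comparison between the cores would require.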